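A Fluorine in Place of the Nitro Group

The source may hold more compounds than are shown below. What is called first, only, known or untested is meant among the compounds shown, and "the series" means these compounds.

Measured so far in a functional assay on MCF7 cells (Homo sapiens) for antiproliferative activity, read by MTT assay, with a stated time of 72 h; a higher number here means a weaker inhibitor, a lower number a stronger inhibitor:
compound 1, `COc1cc(-n2cnc3ccc(-c4ccc([N+](=O)[O-])cc4)cc32)cc(OC)c1OC`: 740 nM
compound 2, `COc1cc(-n2cnc3ccc(-c4cccc(N)c4)cc32)cc(OC)c1OC`: 180 nM
compound 3, `COc1cc(-n2cnc3ccc(-c4ccc(Cl)cc4Cl)cc32)cc(OC)c1OC`: 5420 nM

All three compounds share one core and differ only in the aryl group attached to it. Compound 1 stands second highest of the three numbers in this assay. Its nearest neighbour is compound 2, reached by a 4.1-fold lower number from compound 1 to compound 2 (0.61 log units; beyond the scatter); its furthest is compound 3, reached by a 7.3-fold higher number from compound 1 to compound 3 (0.86 log units; beyond the scatter). Both steps move the number beyond the scatter, one down and one up, so the group on this ring clearly matters.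

Compound 4 `COc1cc(-n2cnc3ccc(-c4ccc(F)cc4)cc32)cc(OC)c1OC` has not yet been measured. It differs from compound 1 in one place: fluoro in place of nitro on an aromatic carbon. Neither measured step exchanges a nitro group for a fluoro group, so none of them bears on this change directly; they only show that the pendant ring can shift the number in either direction. For the measured compounds named here, with no closer precedent, compound 4 is expected to stay near compound 1, with a 1.4-fold higher number from compound 1 to compound 4 (0.13 log units; within the scatter) likely inside the scatter. Compound 4 is therefore estimated at 1000 nM in this assay, expected to fall between 300 nM and 3500 nM.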

Compound 4, half-maximal inhibitory concentration: 1770 nM
Compound 4: middle estimate off by 1.8-fold (0.25 log units), on the low side, and the stated range covers the measured number.
By their numbers in this assay, from the lowest: compound 2; then compound 1; then compound 4; then compound 3.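

In this assay the exchange of nitro for fluoro on this ring is a real change rather than a silent one (a 2.4-fold higher number from compound 1 to compound 4 (0.38 log units; beyond the scatter)), so the two groups cannot be treated as equivalent at this place, even though neither sits at an end of the range. The 4-fluorophenyl group lands inside the span set by the earlier aryl groups, clearly separated from the 2,4-dichlorophenyl group (a 3.1-fold lower number from compound 3 to compound 4 (0.49 log units; beyond the scatter)) and further still from the 3-aminophenyl group (a 9.8-fold higher number from compound 2 to compound 4 (0.99 log units; beyond the scatter)), which leaves all four compounds apart from one another, with compound 2 lowest and compound 3 highest. Nothing available gives a reason for these shifts.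

With the amine of compound 2 carried as 3-aminophenyl and the nitro group of compound 1 as 4-nitrophenyl, the compounds shown do not separate the effect of the group from the effect of where it sits on the ring. On these data alone, it also remains open how a 4-aminophenyl or a 4-carboxyphenyl group would read in this assay against the four numbers now in hand.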